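Acetamide to cyclopropylamide on the shared core

A few compounds are considered here, and "the series" means these few. Any claim that something is new, unique, unknown or untested is made for them only; others in the source may bear on it.

Of the compounds shown here, two of one series have been measured in a functional assay for antagonist activity at C-X-C chemokine receptor type 3 (Homo sapiens); a higher number here means a weaker inhibitor, a lower number a stronger inhibitor. Compound 1 `CCNC(=N)c1cnc(N2CCN(C3CCN(Cc4ccc(Cl)cc4)CC3)[C@@H](C)C2)c(Cl)c1` gives 83 nM. Among the measured compounds shown here, compound 2 `CC(=O)Nc1cnc(N2CCN(C3CCN(Cc4ccc(Cl)cc4)CC3)[C@@H](C)C2)c(Cl)c1` gives 8 nM, and the step of a 10-fold lower number from compound 1 to compound 2 (1.02 log units; beyond the scatter) is the only measured step. For the measured compounds named here, compound 2 therefore stands at the lowest of the two numbers, with compound 1 the only neighbour.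

Compound 3 `C[C@H]1CN(c2ncc(NC(=O)C3CC3)cc2Cl)CCN1C1CCN(Cc2ccc(Cl)cc2)CC1` differs from compound 2 by cyclopropyl in place of methyl on a carbonyl carbon. Going by the values given here, the one measured step swaps the whole group on the aromatic carbon and does not touch the carbonyl substituent, so no measured step bears directly on this change. Without a precedent, the expectation is for no step beyond the scatter, so that no change at the digits printed from compound 2 to compound 3 (within the scatter) is expected in this assay. Compound 3 is estimated at 8 nM, within a range from 3 nM to 25 nM.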

Compound 3, half-maximal inhibitory concentration: 20 nM
Compound 3: the middle estimate sits 2.5-fold (0.40 log units) below what was measured; the range from low to high includes it.
By their numbers in this assay, from the lowest: compound 2; then compound 3; then compound 1.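

The carbonyl substituent is not a silent position in this assay: cyclopropyl in place of methyl on a carbonyl carbon gives a 2.5-fold higher number from compound 2 to compound 3 (0.40 log units; beyond the scatter), a modest step but one beyond the scatter. The cyclopropyl amide still keeps a clear margin over the group carried by compound 1, with a 4.2-fold lower number from compound 1 to compound 3 (0.62 log units; beyond the scatter), so compound 2 and compound 3 both have lower numbers than compound 1, although the margin is smaller than a 10-fold lower number from compound 1 to compound 2 (1.02 log units; beyond the scatter). No available evidence accounts for the difference between the methyl and cyclopropyl amides.

With only these two groups on the carbonyl carbon, the compounds do not show whether an ethyl or tert-butyl group would follow cyclopropyl or methyl. They also leave open how a methoxy group or an amine at the same carbon would read in this assay.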